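Lengthening the Thioether Linker of a Boronic Acid Series

The source may hold more compounds than are shown below. What is called first, only, known or untested is meant among the compounds shown, and "the series" means these compounds.

Compound 1 `CC(C)C[C@H](NC(=O)CSc1cc(NS(=O)(=O)c2ccc(Cl)cc2)c2ccccc2c1O)B(O)O` carries the lowest number of the two measured compounds in a functional assay on MDA-MB-231 cells (Homo sapiens) for antiproliferative activity, read by sulforhodamine B assay, with a stated time of 72 h (a lower number here means a stronger inhibitor, a higher number a weaker inhibitor), where compound 1 gives 6190 nM. Its nearest neighbour, compound 2 `CC(C)C[C@H](NC(=O)CSc1cc(NS(=O)(=O)c2cccs2)c2ccccc2c1O)B(O)O`, differs only in the group on the sulfonyl sulfur; in this assay compound 2 gives 6520 nM, and the step of a 1.1-fold higher number from compound 1 to compound 2 (0.02 log units; within the scatter) lies within the scatter. Compound 3 `CC(C)C[C@H](NC(=O)CCSc1cc(NS(=O)(=O)c2ccc(Cl)cc2)c2ccccc2c1O)B(O)O` is not yet measured. It differs from compound 1 as follows: a group of 12 heavy atoms (7 carbon, 1 boron, 1 nitrogen, 3 oxygen; no ring) in place of a group of 11 heavy atoms (6 carbon, 1 boron, 1 nitrogen, 3 oxygen; no ring), on a saturated chain carbon bound to a sulfur. For the measured compounds named here, the single measured step concerns the sulfonyl substituent, not the saturated chain, so no comparable step exists for this change. Going by the values given here, compound 3 is therefore expected to stay near compound 1, because a 1.1-fold higher number from compound 1 to compound 2 (0.02 log units; within the scatter) shows only that a change elsewhere left the number unmoved. The expected step of a 1.1-fold higher number from compound 1 to compound 3 (0.05 log units; within the scatter) is accordingly small. Compound 3 is estimated at 7000 nM, within a wide range from 2500 nM to 20000 nM.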

Compound 3, half-maximal inhibitory concentration: 4090 nM
The estimate for compound 3 lay 1.7-fold (0.23 log units) above the measured number, and the stated range covers the measured number.
By their numbers in this assay, from the lowest: compounds 3, 1 and 2 (each within the scatter of the next).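

In this assay, the group of 12 heavy atoms in place of the group of 11 heavy atoms, on a saturated chain carbon bound to a sulfur, gives a 1.5-fold lower number from compound 1 to compound 3 (0.18 log units; within the scatter). For the compounds shown here, this is the first reading at this position, and it shows that this lengthening of the chain leaves the number within the scatter. Going by these compounds alone, the saturated chain thus joins the group on the sulfonyl sulfur as a second place where a single change has not moved the number beyond the scatter, though only one change has been read at each place. Nothing measured here bears on the size of this step.

As far as these compounds go, whether a longer chain at this place would take the number beyond the scatter remains open. So does whether an amine or a carboxylic acid on this chain, or the same lengthening with thiophen-2-yl on the sulfonyl sulfur, would leave it there.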